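This account rests on a few compounds, and the source may have more. Where it says the series, first, only, none or still open, it means among the compounds named here.

Of the compounds shown here, three built on one shared core have been measured in an assay on RBL-1 cells with Polyunsaturated fatty acid 5-lipoxygenase (Rattus norvegicus) as the target; a higher number here means a weaker inhibitor, a lower number a stronger inhibitor. Compound 1 `Cc1cc(Cc2ccccc2)c(O)c2ccccc12` gives 20 nM. Compound 2 `Oc1c(Cc2ccccc2)cc(-c2ccccc2)c2ccccc12` gives 56 nM, and compound 3 `CCOC(=O)c1cc(Cc2ccccc2)c(O)c2ccccc12` gives 160 nM. Compound 3 therefore stands highest of the three numbers in this assay, and since both steps toward it, an 8.0-fold higher number from compound 1 to compound 3 (0.90 log units; beyond the scatter) and a 2.9-fold higher number from compound 2 to compound 3 (0.46 log units; beyond the scatter), go upward beyond the scatter, it is the weakest inhibitor of the three.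

Compound 4 `CS(=O)(=O)c1cc(Cc2ccccc2)c(O)c2ccccc12` differs from compound 3 in one place: methylsulfonyl in place of ethoxycarbonyl on an aromatic carbon. The measured steps that bear on this are the two that changed the same aromatic carbon, an 8.0-fold higher number from compound 1 to compound 3 (0.90 log units; beyond the scatter) and a 2.9-fold higher number from compound 2 to compound 3 (0.46 log units; beyond the scatter), both of modest size and both upward. None of them involves a methylsulfonyl group, so there is no direct measurement of how that group behaves here. A change of at most modest size in this assay is expected, with the direction uncertain and no step beyond the scatter the most likely outcome. For compound 4 the estimate in this assay is 200 nM, with a range from 60 nM to 700 nM, meaning an expected step of a 1.3-fold higher number from compound 3 to compound 4 (0.10 log units; within the scatter).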

Compound 4, half-maximal inhibitory concentration: 40000 nM
Compound 4: middle estimate off by 200-fold (2.30 log units), on the low side, and the stated range ends below it.
By their numbers in this assay, from the lowest: compound 1; then compound 2; then compound 3; then compound 4.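

Within the data shown here, this position turns out to be far less forgiving than the earlier compounds suggested: methyl, phenyl and ethoxycarbonyl differ only modestly in this assay, whereas methylsulfonyl brings a 250-fold higher number from compound 3 to compound 4 (2.40 log units; beyond the scatter), even though the leaving and entering groups have the same count of hydrogen-bond acceptors and neither carries a net charge. The loss is as stark against the other two groups, with a 710-fold higher number from compound 2 to compound 4 (2.85 log units; beyond the scatter) and a 2000-fold higher number from compound 1 to compound 4 (3.30 log units; beyond the scatter), which makes compound 4 the weakest inhibitor of the four. No measurement at hand accounts for this drop.

The compounds shown cannot tell whether the loss is specific to methylsulfonyl: a sulfonamide, a carboxylic acid or an amine on this carbon could land near compound 1 or near compound 4. As far as these compounds go, it also remains open whether the same swap would cost as much with the benzyl or hydroxy group changed.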